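Swapping the furanoyl amide cap for a dichlorobenzoyl cap

A few compounds are considered here, and "the series" means these few. Any claim that something is new, unique, unknown or untested is made for them only; others in the source may bear on it.

Measured compounds:
- compound 1 `COc1cc(/C=C/C(=O)c2cccc(NC(=O)c3ccco3)c2)ccc1O` gives 0.38 ug/mL
- compound 2 `COc1cc(/C=C/C(=O)c2cccc(N)c2)ccc1O` gives 2.87 ug/mL
- compound 3 `COc1cc(/C=C/C(=O)c2cccc(NC(=O)c3ccccc3)c2)ccc1O` gives 0.37 ug/mL

In a functional assay on HUVEC cells (Homo sapiens) for inhibition (on this read-out lower numbers stand for stronger inhibition and higher numbers for weaker inhibition), compound 1 stands second highest of the three numbers, yet its nearest neighbour, compound 3, sits within the scatter: a 1.0-fold lower number from compound 1 to compound 3 (0.01 log units; within the scatter). Only compound 2, which carries a bare nitrogen in place of the amide cap, lies clearly apart, as a 7.6-fold higher number from compound 1 to compound 2 (0.88 log units; beyond the scatter) shows.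

Compound 4 `COc1cc(/C=C/C(=O)c2cccc(NC(=O)c3ccc(Cl)cc3Cl)c2)ccc1O` is not yet measured. It differs from compound 1 at one place: 2,4-dichlorophenyl in place of furan-2-yl on a carbonyl carbon.

Within the data shown here, two measured steps bear on this. Removing the cap altogether costs potency, as seen from compound 1 to compound 2, while exchanging one aromatic cap for another leaves the number essentially unmoved, as seen in a 1.0-fold lower number from compound 1 to compound 3 (0.01 log units; within the scatter). The step to compound 4 keeps the amide cap and again exchanges one aromatic ring for another, so the step in this assay is expected to stay within the scatter, with no clear direction.

Compound 4 is therefore estimated at 0.38 ug/mL, with a range from 0.15 ug/mL to 0.95 ug/mL, which means an expected step of no change at the digits printed from compound 1 to compound 4 (within the scatter).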

Compound 4, half-maximal inhibitory concentration: 0.4 ug/mL
Compound 4: middle estimate off by 1.1-fold (0.02 log units), on the low side, and the stated range covers the measured number.
By their numbers in this assay, from the lowest: compounds 3, 1 and 4 (each within the scatter of the next); then compound 2.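

In this assay, among these compounds, the cap on the amide tolerates a bigger exchange than the earlier compounds tested: putting 2,4-dichlorophenyl in place of furan-2-yl on the carbonyl carbon brings in two chlorine atoms and removes the ring oxygen, yet the number barely moves (a 1.1-fold higher number from compound 1 to compound 4 (0.02 log units; within the scatter)), and the same holds when this group replaces phenyl (a 1.1-fold higher number from compound 3 to compound 4 (0.03 log units; within the scatter)). The advantage of a capped nitrogen over a bare one also appears with this third cap (a 7.2-fold lower number from compound 2 to compound 4 (0.86 log units; beyond the scatter)), so all three capped compounds stand clearly apart from the uncapped compound 2, while the three caps themselves cannot be told apart in this read-out. Nothing measured here explains why such different aromatic caps read alike.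

All three caps shown are aromatic rings, so it remains open whether a cap without a ring, such as acetyl, or a ring carrying an amine or a carboxylic acid would keep this level of inhibition. The two chlorine atoms also arrive together, which leaves open what a phenyl ring with a single chlorine would give.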